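Adding a Chlorine to a Weakly Cytotoxic Amide

The source may hold more compounds than are shown below. What is called first, only, known or untested is meant among the compounds shown, and "the series" means these compounds.

Measured so far:
compound 1, `COC(=O)c1ccc2c(ccn2-c2ccc(NC(=O)c3ccc(Cl)c(C(F)(F)F)c3)cc2)n1`: 2900 nM
compound 2, `NC(=O)c1ccc2c(ccn2-c2ccc(NC(=O)c3cccc(C(F)(F)F)c3)cc2)n1`: > 10000 nM

In an ADME assay on HS27 cells (Homo sapiens) for cytotoxicity, read by MTT assay (on this read-out lower numbers stand for stronger inhibition and higher numbers for weaker inhibition), compound 1 gives 2900 nM. For compound 2 the assay reports only a limit, > 10000 nM, so compound 2 stands at the limit of > 10000 nM in this assay, at which 1 of the 2 values shown sits, and its true number is not known. Compound 3, `NC(=O)c1ccc2c(ccn2-c2ccc(NC(=O)c3ccc(Cl)c(C(F)(F)F)c3)cc2)n1`, keeps the primary amide of compound 2 and differs from it in one place: chloro in place of hydrogen on an aromatic carbon. Within the data shown here, no pair of measured compounds differs by this change alone, so its effect on the read-out has not been seen directly. Compound 1 carries the same chloro group, but it also bears a methyl ester instead of the primary amide on the shared core, so the gap between compound 1 and the limit of compound 2 cannot be split into two separate contributions. On that basis a move toward stronger inhibition from compound 2 to compound 3 of about an at least 1.6-fold lower number from compound 2 to compound 3 (0.22 log units; that floor lies within the scatter) is expected, but with little confidence. Compound 3 is expected to give 6000 nM, somewhere between 2500 nM and 15000 nM, and it may again be reported only as a limit.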

Compound 3, half-maximal inhibitory concentration: > 10000 nM
Compound 3: only a limit was reported (the forecaster's own chance of this, stated with the estimate: 45%); middle value at least 1.6-fold (0.22 log units) away from the limit.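

In this assay, amino in place of methoxy on a carbonyl carbon gives an at least 3.4-fold higher number from compound 1 to compound 3 (0.53 log units; beyond the scatter), the first readable step among these compounds, and the chloro group is present on both sides of it. Compound 3 gives > 10000 nM, which is a limit of the assay and not a number, so with the primary amide in place, a chloro group ortho to the trifluoromethyl group does not give a value inside the measured range. The step for chloro in place of hydrogen cannot be read, since compound 2 and compound 3 both stop at the same ceiling: the limit of > 10000 nM in this assay, at which 2 of the 3 values shown sit.

Among these compounds, whether the chloro group shifts the read-out at all therefore stays hidden behind that limit, and it could be seen only in a series whose values fall inside the measured range. On these data alone, it also remains open how a carboxylic acid or a nitrile would read in place of the methyl ester or primary amide on the shared core, and whether a bromo group at the chloro position would behave differently.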